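A few compounds are considered here, and "the series" means these few. Any claim that something is new, unique, unknown or untested is made for them only; others in the source may bear on it.

In an ADME assay on MT4 cells (Homo sapiens) for cytotoxicity, read by MTT assay, with a stated time of 96 h (on this read-out higher numbers stand for lower toxicity in this test and lower numbers for higher toxicity in this test), compound 1, with the structure `C/C(=N\NC(N)=S)c1ccc2[nH]c(-c3ccccc3)nc2c1`, gives >= 100000 nM, which is a limit of the assay and not a number. Compound 2, with the structure `C/C(=N\NC(N)=S)c1ccc2[nH]c(-c3ccc(Cl)cc3)nc2c1`, gives 2000 nM in this assay. The change between them, (chloro in place of hydrogen on an aromatic carbon), produced an at least 50-fold lower number from compound 1 to compound 2 (1.69 log units; beyond the scatter), a step whose size rests on (the limit of >= 100000 nM in this assay, at which 1 of the 3 values shown sits). Compound 3, with the structure `CC(=O)c1ccc2c(c1)nc(-c1ccccc1)n2C1CCCCC1`, gives 37000 nM in this assay. How the core of compound 3 differs from that of compound 1 is not broken down here. Compound 4, with the structure `CC(=O)c1ccc2c(c1)nc(-c1ccc(Cl)cc1)n2C1CCCCC1`, is not yet measured; it differs from compound 3 by chloro in place of hydrogen on an aromatic carbon, the same change that separated compound 1 from compound 2, made at the same place. For compound 4 the expected step is a 12-fold lower number from compound 3 to compound 4 (1.09 log units; beyond the scatter), because compound 2 showed an at least 50-fold lower number from compound 1 to compound 2 (1.69 log units; beyond the scatter), though that earlier step is only a lower bound and need not repeat in full on a different core. Compound 4 is therefore estimated at 3000 nM in this assay, between 800 nM and 15000 nM.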

Compound 4, half-maximal cytotoxic concentration: 58000 nM
Beside the measured number, compound 4's estimate is 19-fold (1.29 log units) below it, and the stated range ends below it.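

In this assay, the change from phenyl to 4-chlorophenyl on the core of compound 3 gives a 1.6-fold higher number from compound 3 to compound 4 (0.20 log units; within the scatter), so this pair cannot be told apart in this test. The same change therefore did not carry over from one core to the other with the same result: the same change on two cores in this assay, an at least 50-fold lower number (1.69 log units; beyond the scatter) from compound 1 to compound 2 and a 1.6-fold higher number (0.20 log units; within the scatter) from compound 3 to compound 4, at least 78-fold (1.89 log units) apart, beyond the scatter of two such steps This shows only that the result of adding the chloro can depend on the core; it rests on two pairs, does not show why they part, and the earlier step is only a bound, as compound 1 stands at a limit of the assay and not at a number: the limit of >= 100000 nM in this assay, at which 1 of the 4 values shown sits.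

As far as these compounds go, the two cores differ in more than one place, so it stays open which part of the core decides the outcome, for instance the cyclohexyl group on the ring nitrogen or the side chain holding the thiocarbonyl. From the compounds shown here alone, it also stays open whether another group in the same place, such as fluoro, methoxy or an amine, would follow the chloro on either core.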